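The source may hold more compounds than are shown below. What is called first, only, known or untested is meant among the compounds shown, and "the series" means these compounds.

Measured compounds:
compound 1 `CSc1[nH]ccc2ncnc1-2` gives 4%
compound 2 `OC[C@H]1O[C@@H](n2cnc3c(NCc4ccccc4)nccc32)C[C@@H]1O` gives 15%
compound 3 `CN(C)c1nccc2c1ncn2C1O[C@H](CO)[C@@H](O)[C@H]1O` gives 0%

All three values come from a functional assay (Homo sapiens) for inhibition of Nucleic Acid, tested at 100 uM; on this read-out higher numbers stand for more inhibition at the one concentration tested (going by the name of the read-out) and lower numbers for less inhibition. On the numbers shown, compound 2 stands highest of the three: its nearest neighbour is compound 1, whose number lies lower by a margin beyond the scatter, and the furthest is compound 3, whose number lies lower still, also beyond the scatter. Among the measured compounds shown here, no pair of measured compounds differs in one place only, so no measured step can be drawn on.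

Compound 4 `[N-]=[N+]=Nc1nccc2c1ncn2[C@H]1C[C@H](O)[C@@H](CO)O1` has not been measured in this assay. Relative to compound 2 the change is azido in place of benzylamino on an aromatic carbon. Compound 3, which also lacks the benzylamino of compound 2, sits at the bottom of the set, and compound 4 shares with it the absence of that group. A downward step from compound 2 is therefore expected, small enough that it may stay within the scatter: a number 9 percentage points lower from compound 2 to compound 4 (within the scatter) is the estimated step. For compound 4 the expected value in this assay is 6%, within a range from 0% to 18%.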

Compound 4, a percentage reported as inhibition, at one concentration (the size of the read-out at that concentration, not a potency): 4%
Beside the measured number, compound 4's estimate is 2 percentage points above it; measured number inside the range.
By their numbers in this assay, from the lowest: compounds 3, 1 and 4 (each within the scatter of the next); then compound 2.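

In this assay, the aromatic carbon next to the ring nitrogen now has its first measured step: azido in place of benzylamino gives a number 11 percentage points lower from compound 2 to compound 4 (beyond the scatter). Among the compounds shown here, the pair differs in this one place only, so the change at this carbon can be read directly, which no earlier pair allowed. Both numbers are single-concentration read-outs at the low end of the scale, and no measurement shown explains the step.

Still open, on these data alone, is whether the step follows the benzene ring of benzylamino or its linking nitrogen: an unsubstituted amine, a benzyloxy group or a longer chain such as phenethylamino on this carbon would bear on that. Also open, as far as these compounds go, is whether the same step holds when the rest of the shared core carries other groups.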